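The compounds below may be only part of what the source reports. "The series", "measured", "known", "first", "only" and "open" are said of these compounds alone.

Measured in a functional assay on HeLa cells (Homo sapiens) for inhibition, read by CCK-8 assay, with a stated time of 48 h; a higher number here means a weaker inhibitor, a lower number a stronger inhibitor:

- Compound 1 `COc1cc(-c2ccnc3cc(-c4ccc(Cl)cc4)nn23)cc(OC)c1OC` gives 1490 nM
- Compound 2 `COc1cc(-c2ccnc3cc(-c4ccccc4)nn23)cc(OC)c1OC` gives 458 nM
- Compound 3 `COc1cc(-c2ccnc3cc(-c4cn(C)c5ccccc45)nn23)cc(OC)c1OC` gives 399 nM

Compound 3 stands level with compound 2 and clear of compound 1. The move a 1.1-fold lower number from compound 2 to compound 3 (0.06 log units; within the scatter) stays within the scatter, while the move a 3.7-fold lower number from compound 1 to compound 3 (0.57 log units; beyond the scatter) goes beyond it.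

Compound 4 `C=Cc1ccc(-c2cc3nccc(-c4cc(OC)c(OC)c(OC)c4)n3n2)cc1` has 4-vinylphenyl in place of the 1-methyl-1H-indol-3-yl of compound 3 on an aromatic carbon: 4-vinylphenyl in place of 1-methyl-1H-indol-3-yl on an aromatic carbon.

Within the data shown here, the closest precedent is the 4-chlorophenyl of compound 1, which also carries a group on the phenyl ring at the 4-position. Removing that chloro gave a modest change a 3.3-fold lower number from compound 1 to compound 2 (0.51 log units; beyond the scatter). The swap between phenyl and 1-methyl-1H-indol-3-yl gave no change beyond the scatter, as the step of a 1.1-fold lower number from compound 2 to compound 3 (0.06 log units; within the scatter) shows. Among the measured compounds shown here, no vinyl compound has been measured, so the comparison with chloro remains uncertain.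

A modest rise is therefore expected, somewhat smaller than the chloro step, and the estimated step is a 2.1-fold higher number from compound 3 to compound 4 (0.33 log units; beyond the scatter). For compound 4 the estimated value is 850 nM, with an expected range from 300 nM to 2400 nM.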

Compound 4, half-maximal inhibitory concentration: 882 nM
For compound 4 the middle estimate is 1.0-fold (0.02 log units) below the measured one; measured number inside the range.
By their numbers in this assay, from the lowest: compounds 3, 2, 4 and 1 (each within the scatter of the next, the first and the last beyond it).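

In this assay, 4-vinylphenyl in place of 1-methyl-1H-indol-3-yl gives a 2.2-fold higher number from compound 3 to compound 4 (0.34 log units; beyond the scatter) at this position, so the indole-bearing compound 3 now has a measured step beyond the scatter to a second substituted phenyl, not only to the 4-chlorophenyl of compound 1. Vinyl in place of hydrogen gives a 1.9-fold higher number from compound 2 to compound 4 (0.28 log units; within the scatter) while vinyl in place of chloro gives a 1.7-fold lower number from compound 1 to compound 4 (0.23 log units; within the scatter) and so compound 4 cannot be told apart from either compound 2 or compound 1, even though those two differ from each other beyond the scatter. No evidence on the cause of these steps is available here.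

Still open, on these data alone, is whether an amine, a carboxylic acid or a longer chain in place of the vinyl would separate from compound 2 beyond the scatter. The compounds shown also do not say how a group other than chloro or vinyl would read on this phenyl ring.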